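Varying the group on the ring nitrogen of the shared core

A few compounds are considered here, and "the series" means these few. Any claim that something is new, unique, unknown or untested is made for them only; others in the source may bear on it.

Measured so far:
compound 1 `Nc1scc(CN2CCN(c3cccc(C(F)(F)F)c3)CC2)c1C(=O)c1ccc(Cl)cc1`: -80%
compound 2 `Nc1scc(CN2CCN(CCCc3ccc(Cl)cc3)CC2)c1C(=O)c1ccc(Cl)cc1`: -76%

In a functional assay on CHO cells with adenosine receptor A1 (Homo sapiens) as the target, read by cAMP accumulation and immunoassay, with a stated time of 6 min, tested at 10 uM (a lower number here means a stronger effect, a higher number a weaker effect of the compound at the concentration tested), compound 1 gives -80%, the lowest of the two numbers available; the nearest is compound 2, which gives -76%, and the gap between them is within the scatter. Among the compounds with values here, the one measured step, a number 4 percentage points higher from compound 1 to compound 2 (within the scatter), accordingly shows no movement beyond the scatter. Compound 3 `Nc1scc(CN2CCN(c3ccccc3Cl)CC2)c1C(=O)c1ccc(Cl)cc1` is not yet measured. It differs from compound 1 in one place: 2-chlorophenyl in place of 3-(trifluoromethyl)phenyl on an amine nitrogen in a ring. Within the data shown here, the only step that bears on this change is a number 4 percentage points higher from compound 1 to compound 2 (within the scatter), where another exchange on the same ring nitrogen left the number essentially unchanged. With no step beyond the scatter anywhere in the series, no change beyond the scatter is expected from compound 1 to compound 3, and the expected step is a number 2 percentage points higher from compound 1 to compound 3 (within the scatter). Compound 3 is therefore estimated at -78%, with a range from -92% to -60%.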

Compound 3, a percentage reported as activity, at one concentration (the size of the read-out at that concentration, not a potency): -18%
Estimate against measurement, compound 3: 60 percentage points below, and the stated range ends below it.
By their numbers in this assay, from the lowest: compounds 1 and 2 (each within the scatter of the next); then compound 3.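

In this assay the group on the amine nitrogen in the ring is not a free exchange, as two large steps show (a number 62 percentage points higher from compound 1 to compound 3 (beyond the scatter)) and (a number 58 percentage points higher from compound 2 to compound 3 (beyond the scatter)), whereas the earlier pair alone showed no movement beyond the scatter. 3-(Trifluoromethyl)phenyl and 2-chlorophenyl each carry one six-membered aromatic ring of carbon only and no hydrogen-bond donors or acceptors, so those counts stay the same across the large step, while the group on that ring and its place on it change together. Nothing at hand gives a reason for these steps.

Open, on these data alone, is whether the step follows the chlorine or its place: 3-chlorophenyl and 2-(trifluoromethyl)phenyl on the same nitrogen would separate the two. Also open, as far as these compounds go, is how an unsubstituted phenyl or a pyridine ring there would read.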